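From Chloro to Trifluoromethyl: Expecting Compound 3

The source may report more compounds than this note shows. Statements on the series, on what has been measured and on what is new or still open speak of the compounds shown alone.

Compound 1 `O=C(Nc1ccccc1F)C(Cl)Cl`: 87500 nM
Compound 2 `O=C(Nc1cccc(Cl)c1)C(Cl)Cl`: 14800 nM

Of the compounds shown here, two have been measured in a functional assay on A549 cells (Homo sapiens) for antiproliferative activity, read by MTT assay, with a stated time of 72 h; a lower number here means a stronger inhibitor, a higher number a weaker inhibitor. Compound 2 gives the lowest number of the two, and compound 1 sits well above it, a gap beyond the scatter. The unmeasured compound 3 `O=C(Nc1cccc(C(F)(F)F)c1)C(Cl)Cl` differs from compound 2 in one place: trifluoromethyl in place of chloro on an aromatic carbon. Among the measured compounds shown here, no measured pair shows this change, so its effect cannot be read off the data. Compound 3 is expected to land close to compound 2, with a small step of a 1.5-fold lower number from compound 2 to compound 3 (0.17 log units; within the scatter) that may not exceed the scatter. The estimate for compound 3 is 10000 nM, within a range from 3000 nM to 40000 nM.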

Compound 3, half-maximal inhibitory concentration: 12200 nM
Compound 3: the middle estimate sits 1.2-fold (0.09 log units) below what was measured; measured number inside the range.
By their numbers in this assay, from the lowest: compounds 3 and 2 (each within the scatter of the next); then compound 1.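

In this assay, the pair shows a 1.2-fold lower number from compound 2 to compound 3 (0.08 log units; within the scatter), so the two compounds cannot be told apart here. At this aromatic carbon, trifluoromethyl, with 4 heavy atoms, can therefore stand in place of chloro, with 1 heavy atom, without a difference this read-out can separate. No measurement is at hand that explains this result.

As far as these compounds go, whether an amine or a carboxylic acid on this same carbon would give a similar number remains open. So does whether this swap would behave the same way on another carbon of the ring.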